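Trimethoxyphenyl pyrazoles: methoxy removal and cell growth inhibition

The source may report more compounds than this note shows. Statements on the series, on what has been measured and on what is new or still open speak of the compounds shown alone.

Compound 1 `COc1cc(-c2cc(/C=C/C(=O)c3ccc(N)cc3)[nH]n2)cc(OC)c1OC` and compound 3 `COc1ccc(-c2cc(/C=C/C(=O)c3ccc(N)cc3)[nH]n2)cc1OC` share one core; in a functional assay on MDA-MB-231 cells (Homo sapiens) for inhibition, read by MTT assay, with a stated time of 48 h (a higher number here means a weaker inhibitor, a lower number a stronger inhibitor), compound 1 gives 2000 nM and compound 3 gives 2200 nM. The change between them, (hydrogen in place of methoxy on an aromatic carbon), gave a 1.1-fold higher number from compound 1 to compound 3 (0.04 log units; within the scatter). Compound 2 `COc1ccc2c(c1)C/C(=C\c1cc(-c3cc(OC)c(OC)c(OC)c3)n[nH]1)C2=O` gives 2000 nM in this assay; the difference between its core and that of compound 1 is not broken down here. Compound 4 `COc1cc(-c2cc(/C=C3\Cc4ccccc4C3=O)[nH]n2)cc(OC)c1OC` is unmeasured. It differs from compound 2 by hydrogen in place of methoxy on an aromatic carbon; this is the same kind of change as that from compound 1 to compound 3, but here the place is part of a fused or bridged system of two rings, meta and para to a fused ring, rather than ortho and meta to methoxy groups. Going by the values given here, compound 4 is expected to give 2200 nM (range 1000 nM to 5000 nM), the expected step of a 1.1-fold higher number from compound 2 to compound 4 (0.04 log units; within the scatter) resting on the single small step of a 1.1-fold higher number from compound 1 to compound 3 (0.04 log units; within the scatter).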

Compound 4, half-maximal inhibitory concentration: 7100 nM
Compound 4: middle estimate off by 3.2-fold (0.51 log units), on the low side; measured number above the stated range.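

In this assay, hydrogen in place of methoxy gives a 3.6-fold higher number from compound 2 to compound 4 (0.55 log units; beyond the scatter), so the step seen on the earlier core does not carry over at the same size: the same change on two cores in this assay, a 1.1-fold higher number (0.04 log units; within the scatter) from compound 1 to compound 3 and a 3.6-fold higher number (0.55 log units; beyond the scatter) from compound 2 to compound 4, 3.2-fold (0.51 log units) apart, beyond the scatter of two such steps. The two steps also differ in place, since on compound 2 the methoxy sits on an aromatic carbon that is part of a fused or bridged system of two rings, meta to a fused ring and para to a fused ring. With one pair per core, the data do not separate the core from the place and give no rule for other cores.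

Open, as far as these compounds go, is how an amine or an ethoxy group at this place on the fused system would compare with compound 2 and compound 4.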